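This account rests on a few compounds, and the source may have more. Where it says the series, first, only, none or still open, it means among the compounds named here.

Three measured compounds share one core. Compound 1 `CCCc1nc(-c2ccccc2)c(CNCCN2CCN(c3ccc(C)cc3)CC2)o1` gives 48.1% in an assay on HEK293 cells for inhibition of Voltage-dependent T-type calcium channel subunit alpha-1G (Homo sapiens), read by fluorescence, tested at 10 uM; a lower number here means less inhibition, a higher number more inhibition at the concentration tested (going by the name of the read-out). Compound 3 `CCCc1nc(-c2ccccc2)c(CNCCN2CCN(c3ccc(OC)cc3)CC2)o1` gives 51.5% in this assay; the step of a number 3.4 percentage points higher from compound 1 to compound 3 (within the scatter) follows a methoxy in place of methyl on an aromatic carbon. Compound 2 `Cc1nc(-c2ccccc2)c(CNCCCN2CCN(c3ccc(Cl)cc3)CC2)o1` gives 38.1% in this assay, the lowest of the three numbers, with compound 1 nearest, within the scatter, and compound 3 furthest, beyond it. Compound 4 `CCCc1nc(-c2ccccc2)c(CNCCCN2CCN(c3ccc(Cl)cc3)CC2)o1` differs from compound 2 by ethyl in place of hydrogen on a saturated chain carbon bound to an aromatic carbon. Among the measured compounds shown here, no measured step isolates this change; compounds 1 and 3 carry the propyl but differ from compound 2 in further places, so their higher numbers are only a loose hint. A modest rise is expected, a number 7.9 percentage points higher from compound 2 to compound 4 (within the scatter), possibly within the scatter. Compound 4 is estimated at 46%, between 30% and 62%.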

Compound 4, a percentage reported as inhibition, at one concentration (the size of the read-out at that concentration, not a potency): 63.3%
Estimate against measurement, compound 4: 17.3 percentage points below; measured number above the stated range.
By their numbers in this assay, from the lowest: compounds 2, 1 and 3 (each within the scatter of the next, the first and the last beyond it); then compound 4.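

This pair isolates ethyl in place of hydrogen on a saturated chain carbon bound to an aromatic carbon, which can also be read as methyl to propyl. In this assay, the change gives a number 25.2 percentage points higher from compound 2 to compound 4 (beyond the scatter), so this one difference alone can move the read-out beyond the scatter. The earlier propyl compounds differ from compound 2 in further places and could not show this, and nothing shown explains the rise. Going by these compounds, whether a butyl chain or a cyclopropyl ring here would raise the number further remains open. So does whether methyl to propyl gives a similar step in other compounds.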